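Aryl swaps on the enone: compound 3 to compound 4

A few compounds are considered here, and "the series" means these few. Any claim that something is new, unique, unknown or untested is made for them only; others in the source may bear on it.

Values in a functional assay on MDA-MB-231 cells (Homo sapiens) for cytotoxicity, read by MTT assay, with a stated time of 48 h; a higher number here means a weaker inhibitor, a lower number a stronger inhibitor:
compound 1 `O=C(/C=C/c1ccc2c(c1)B(O)OC2)c1cccnc1`: 11400 nM
compound 2 `O=C(/C=C/c1ccc2c(c1)B(O)OC2)c1ccc(I)cc1`: 14900 nM
compound 3 `O=C(/C=C/c1ccc2c(c1)B(O)OC2)c1ccc(O)cc1`: 25600 nM

Compound 3 carries the highest number of the three. For the measured compounds named here, its nearest neighbour is compound 2, and that gap is a 1.7-fold higher number from compound 2 to compound 3 (0.24 log units; within the scatter), while the other gap is a 2.2-fold higher number from compound 1 to compound 3 (0.35 log units; beyond the scatter), the only step of the three that reaches beyond the scatter. The remaining step, a 1.3-fold higher number from compound 1 to compound 2 (0.12 log units; within the scatter), is also within the scatter. All three measured compounds share the same core and differ only in the aryl group on the carbonyl carbon; the spread of numbers across the whole set is narrow.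

Compound 4 `O=C(/C=C/c1ccc2c(c1)B(O)OC2)c1ccccc1O` is the unmeasured member. Its change from compound 3 is 2-hydroxyphenyl in place of 4-hydroxyphenyl on a carbonyl carbon. Going by the values given here, no measured step moves a substituent around the same ring; the three aryl swaps above are the only guide, and they show small movements. The step from compound 3 to compound 4 is therefore expected to be a 1.2-fold lower number from compound 3 to compound 4 (0.07 log units; within the scatter), with no direction that can be called beyond the scatter. Compound 4 is estimated at 22000 nM in this assay, with a range from 9000 nM to 55000 nM.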

Compound 4, half-maximal inhibitory concentration: 16900 nM
Beside the measured number, compound 4's estimate is 1.3-fold (0.11 log units) above it; low and high end bracket the measured number.
By their numbers in this assay, from the lowest: compounds 1, 2, 4 and 3 (each within the scatter of the next, the first and the last beyond it).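

In this assay, for the compounds shown here, 2-hydroxyphenyl in place of 4-hydroxyphenyl on the carbonyl carbon gives a 1.5-fold lower number from compound 3 to compound 4 (0.18 log units; within the scatter), the first reading of a hydroxy group moved around this ring, and the move does not shift the number beyond the scatter. Compound 4 also lies within the scatter of both non-hydroxy aryl compounds, with a 1.1-fold higher number from compound 2 to compound 4 (0.05 log units; within the scatter) and a 1.5-fold higher number from compound 1 to compound 4 (0.17 log units; within the scatter), whereas the 4-hydroxyphenyl compound is separated from the pyridin-3-yl compound by a 2.2-fold higher number from compound 1 to compound 3 (0.35 log units; beyond the scatter), so that single gap in the set is not shared by the 2-hydroxyphenyl compound. Nothing available on the series offers an explanation for these values.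

Open is whether any group on this aryl ring can take the number outside this narrow band, for example an amine, a carboxylic acid or a longer chain such as butyl, since all four aryl groups shown give closely grouped values. Also open, going by these compounds, is whether this insensitivity at the carbonyl carbon would hold with a change to the shared core or in a reading other than this assay.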